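Working notes: chain in place of phenyl on the ring nitrogen

This account rests on a few compounds, and the source may have more. Where it says the series, first, only, none or still open, it means among the compounds named here.

For the measured compounds named here, compound 3 `CN1CCN(c2nc3ccccc3n2-c2ccccc2)CC1` gives 760 nM in a functional assay on ileum for inhibition of histamine H1 receptor (Cavia porcellus) (on this read-out higher numbers stand for weaker inhibition and lower numbers for stronger inhibition), and stands second highest of the three numbers so far. Compound 1 `CN1CCN(c2nc3ccccc3n2CCO)CC1` gives 410 nM and compound 2 `CCCC(C)n1c(N2CCN(C)CC2)nc2ccccc21` gives 1400 nM in the same assay. Of the measured steps, a 1.9-fold higher number from compound 1 to compound 3 (0.27 log units; within the scatter) and a 1.8-fold lower number from compound 2 to compound 3 (0.27 log units; within the scatter) lie within the scatter, while only a 3.4-fold higher number from compound 1 to compound 2 (0.53 log units; beyond the scatter) is beyond it. Compound 4 `CCCCCCCn1c(N2CCN(C)CC2)nc2ccccc21` differs from compound 3 by heptyl in place of phenyl on an aromatic nitrogen. The step bearing most directly on this change is a 1.8-fold lower number from compound 2 to compound 3 (0.27 log units; within the scatter), which ran from an alkyl chain to phenyl and was within the scatter, so for the reverse direction, toward a longer chain, at most a small rise in this assay is expected: a 1.7-fold higher number from compound 3 to compound 4 (0.23 log units; within the scatter). Compound 4 is therefore estimated at 1300 nM, with a range of 500 nM to 3500 nM.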

Compound 4, half-maximal inhibitory concentration: 150 nM
Compound 4: the middle estimate sits 8.7-fold (0.94 log units) above what was measured; measured number below the stated range.
By their numbers in this assay, from the lowest: compound 4; then compounds 1, 3 and 2 (each within the scatter of the next, the first and the last beyond it).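

For the compounds shown here, at this ring nitrogen, in this assay, a long unbranched chain gives the lowest number so far: heptyl in place of phenyl gives (a 5.1-fold lower number from compound 3 to compound 4 (0.70 log units; beyond the scatter)) and heptyl in place of 1-methylbutyl gives (a 9.3-fold lower number from compound 2 to compound 4 (0.97 log units; beyond the scatter)). An alkyl group here therefore does not by itself raise the number, and the two alkyl groups lie far apart. Pentyl in place of hydroxy on the saturated chain also lowers it (a 2.7-fold lower number from compound 1 to compound 4 (0.44 log units; beyond the scatter)).

On these data alone, whether length or branching separates compound 2 from compound 4 stays open, and an unbranched pentyl or a longer nonyl chain would bear on that. Nothing measured here explains these steps.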